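The source may hold more compounds than are shown below. What is called first, only, known or untested is meant among the compounds shown, and "the series" means these compounds.

Compound 1 `CN(C)CCn1cnnc1-c1cc(Oc2ccc(NC(=O)N/N=C/c3c[nH]c4ccccc34)cc2F)ccn1` gives 1300 nM in a functional assay on HT-29 cells (Homo sapiens) for cytotoxicity, read by MTT assay, with a stated time of 72 h; on this read-out higher numbers stand for weaker inhibition and lower numbers for stronger inhibition.
Compound 2 `CN(C)CCn1cnnc1-c1cc(Oc2ccc(NC(=O)N/N=C/c3ccccc3)cc2F)ccn1` gives 1120 nM in this assay.
Compound 3 `CN(C)CCn1cnnc1-c1cc(Oc2ccc(NC(=O)N/N=C/c3ccc(Cl)cc3)cc2F)ccn1` gives 530 nM in this assay.

Compound 3 holds the lowest number of the three, with a 2.1-fold lower number from compound 2 to compound 3 (0.32 log units; beyond the scatter) and a 2.5-fold lower number from compound 1 to compound 3 (0.39 log units; beyond the scatter) both beyond the scatter. Compound 4 `CN(C)CCn1cnnc1-c1cc(Oc2ccc(NC(=O)N/N=C/c3ccc(O)cc3O)cc2F)ccn1` differs from it by 2,4-dihydroxyphenyl in place of 4-chlorophenyl on a carbon with a double bond to nitrogen. Going by the values given here, the only step bearing on it is a 2.1-fold lower number from compound 2 to compound 3 (0.32 log units; beyond the scatter), which shows what the chloro contributed; nothing among the measured compounds speaks to hydroxyl groups at this position. Taking the chloro away is therefore expected to cost about what it gained, and the two hydroxyl groups are an open question. Compound 4 is thus estimated at 1200 nM, between 500 nM and 3500 nM, a step of a 2.3-fold higher number from compound 3 to compound 4 (0.35 log units; beyond the scatter).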

Compound 4, half-maximal inhibitory concentration: 52600 nM
Beside the measured number, compound 4's estimate is 44-fold (1.64 log units) below it; measured number outside the range, above it.
By their numbers in this assay, from the lowest: compound 3; then compounds 2 and 1 (each within the scatter of the next); then compound 4.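

On the carbon with a double bond to nitrogen, 2,4-dihydroxyphenyl produces far larger steps in this assay than the earlier groups did, whichever group it replaces: 4-chlorophenyl (a 99-fold higher number from compound 3 to compound 4 (2.00 log units; beyond the scatter)), phenyl (a 47-fold higher number from compound 2 to compound 4 (1.67 log units; beyond the scatter)) or 1H-indol-3-yl (a 40-fold higher number from compound 1 to compound 4 (1.61 log units; beyond the scatter)). This position therefore tolerates some aromatic groups far better than others, which the small steps among compounds 1, 2 and 3 did not reveal. No evidence at hand explains the rise.

On these data alone, it remains open whether one hydroxyl group on the phenyl would give the same rise, or whether both are needed. As far as these compounds go, the effect of methoxy groups in place of the hydroxyl groups also remains open.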